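Adding isopropyl to a compound held at the limit

The source may hold more compounds than are shown below. What is called first, only, known or untested is meant among the compounds shown, and "the series" means these compounds.

In a functional assay on Bel-7402 cells (Homo sapiens) for antiproliferative activity, read by MTT assay, with a stated time of 72 h (a higher number here means a weaker inhibitor, a lower number a stronger inhibitor), compound 3 (`COc1cccc(CNCc2c(C(=O)O)n(Cc3ccccc3F)c3ccccc23)c1`) reads > 50000 nM which is a limit and not a number. Compound 2 (`COc1cccc(CNCc2c(C(=O)O)n(Cc3ccccc3F)c3cc(C)ccc23)c1`) reads > 50000 nM which is also a limit. Among the compounds with values here, that leaves a step that the two limits leave unreadable from compound 2 to compound 3 as the only measured step between close neighbours and it offers no size to build on. The record so far shows the limit of > 50000 nM in this assay, at which 2 of the 3 values shown sit, and so gives little to go on.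

Compound 4 (`COc1cccc(CNCc2c(C(=O)O)n(Cc3ccccc3F)c3cc(C(C)C)ccc23)c1`) differs from compound 3 in one place, with isopropyl in place of hydrogen on an aromatic carbon on an aromatic carbon of a six-membered aromatic ring of carbon only. Within the data shown here, compound 1 (`COc1cccc(CNCc2c(C(=O)O)n(Cc3ccc(O)cc3)c3cc(C(C)C)ccc23)c1`) also carries isopropyl, but no measured step isolates that group. Because compound 1 gives a true number of 7080 nM in this assay a shift toward a stronger inhibitor is expected for compound 4. Even so, compound 4 may yet remain at the limit. The expected change is an at least 3.1-fold lower number from compound 3 to compound 4 (0.49 log units; beyond the scatter) in the direction of a lower number, and its size is uncertain. Compound 4 is estimated at 16000 nM within an expected range of 5000 nM to 45000 nM on this reasoning.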

Compound 4, half-maximal inhibitory concentration: 5590 nM
Beside the measured number, compound 4's estimate is 2.9-fold (0.46 log units) above it; the measured number falls inside the stated range.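

In this assay, isopropyl on this aromatic carbon is the first single change shown to bring a compound off the limit, giving an at least 8.9-fold lower number from compound 3 to compound 4 (0.95 log units; beyond the scatter) and, with isopropyl in place of methyl at the same carbon, an at least 8.9-fold lower number from compound 2 to compound 4 (0.95 log units; beyond the scatter). The swap of 4-hydroxyphenyl for 2-fluorophenyl on the saturated chain carbon bound to the aromatic nitrogen gives a 1.3-fold lower number from compound 1 to compound 4 (0.10 log units; within the scatter), so with isopropyl present, this second change makes no difference that can be told from the scatter. Because compound 2 and compound 3 each stand at a limit and not at a number, both large steps give only a smallest possible size, and the true gain from isopropyl could be larger: the limit of > 50000 nM in this assay, at which 2 of the 4 values shown sit.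

On these data alone, only hydrogen, methyl and isopropyl appear on this carbon, so it remains open whether an ethyl or a tert-butyl group there would give a number like that of compound 4 or a different one. As far as these compounds go, it is also open whether the swap on the chain carbon would stay as small with hydrogen or methyl on the aromatic carbon in place of isopropyl.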